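Trading trifluoromethyl for chloro on an aromatic carbon

The source may hold more compounds than are shown below. What is called first, only, known or untested is meant among the compounds shown, and "the series" means these compounds.

Of the compounds shown here, three sharing one core have been measured in a functional assay on B16 cells (Mus musculus) for inhibition; on this read-out higher numbers stand for weaker inhibition and lower numbers for stronger inhibition. Compound 1 `Cc1ccccc1CNC(=O)/C=C/c1ccc(O)c(O)c1` gives 20000 nM, compound 2 `Cc1ccc(CNC(=O)/C=C/c2ccc(O)c(O)c2)cc1` gives 3700 nM, and compound 3 `O=C(/C=C/c1ccc(O)c(O)c1)NCc1cccc(C(F)(F)F)c1` gives 1400 nM. Compound 3 therefore has the lowest number of the three, making it the strongest inhibitor so far, with compound 2 its nearest neighbour.

Compound 4 `O=C(/C=C/c1ccc(O)c(O)c1)NCc1cccc(Cl)c1` has not yet been measured. It differs from compound 3 at one place: chloro in place of trifluoromethyl on an aromatic carbon. Chloro takes the place of trifluoromethyl on an aromatic carbon, meta to a large group.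

Within the data shown here, only one measured step links two compounds that differ in one place: a 5.4-fold lower number from compound 1 to compound 2 (0.73 log units; beyond the scatter). That step moves a methyl group, so it shows that a single change can matter but does not predict this swap. Among the measured compounds shown here, no measured compound carries chloro. With compound 3 already lowest at 1400 nM, a small rise seems likelier than a further drop. The expected step is a 1.4-fold higher number from compound 3 to compound 4 (0.15 log units; within the scatter). Compound 4 is estimated at 2000 nM, with an expected range from 700 nM to 6000 nM.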

Compound 4, half-maximal inhibitory concentration: 6000 nM
Estimate against measurement, compound 4: 3.0-fold (0.48 log units) below; the measured number falls inside the stated range.
By their numbers in this assay, from the lowest: compound 3; then compounds 2 and 4 (each within the scatter of the next); then compound 1.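

In this assay, among these compounds, the group on this aromatic carbon matters: a 4.3-fold higher number from compound 3 to compound 4 (0.63 log units; beyond the scatter) and this is the first measured step to exchange trifluoromethyl for a different group, so the two cannot be treated as interchangeable here. Among the compounds with a single group on the phenyl ring, a 1.6-fold higher number from compound 2 to compound 4 (0.21 log units; within the scatter) so these two cannot be told apart, whereas a 3.3-fold lower number from compound 1 to compound 4 (0.52 log units; beyond the scatter) and that gap is a real one. Nothing available explains why trifluoromethyl gives the lower number.

Going by these compounds, whether a bromo, a methoxy or an amine on this same aromatic carbon would land nearer compound 3 or compound 4 remains open. So does the question of how chloro and trifluoromethyl compare on the other carbons of the ring.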